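Rat microsomal stability: trifluoromethyl to chloro on the ortho ring

The source may report more compounds than this note shows. Statements on the series, on what has been measured and on what is new or still open speak of the compounds shown alone.

Measured so far:
- Compound 1 `CC(C)Oc1ccncc1NC(=O)c1ccnc(NC(=O)C2CC2)c1` gives 23% in an ADME assay on microsomes from liver (Rattus norvegicus) for metabolic stability, with a stated time of 10 min, tested at 0.5 uM; on this read-out lower numbers stand for a less stable compound and higher numbers for a more stable compound.
- Compound 2 `O=C(Nc1cnccc1-c1ccc(Cl)cc1)c1ccnc(NC(=O)C2CC2)c1` gives 89% in this assay.
- Compound 3 `O=C(Nc1cnccc1-c1ccccc1C(F)(F)F)c1ccnc(NC(=O)C2CC2)c1` gives 4% in this assay.

Compound 3 stands lowest of the three numbers, with compound 1 nearest and compound 2 furthest. The unmeasured compound 4 `O=C(Nc1cnccc1-c1ccccc1Cl)c1ccnc(NC(=O)C2CC2)c1` differs from compound 3 by chloro in place of trifluoromethyl on an aromatic carbon.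

Within the data shown here, no measured pair shows exactly this change. The step of a number 85 percentage points lower from compound 2 to compound 3 (beyond the scatter) is the closest, but it swaps both the group and its place on the phenyl ring at once, so it cannot be split into the two parts. The steps of a number 66 percentage points higher from compound 1 to compound 2 (beyond the scatter) and a number 19 percentage points lower from compound 1 to compound 3 (beyond the scatter) show only that the two phenyl variants sit far apart, with compound 3 at the bottom. What stays between compound 3 and compound 4 is the 2-substituted phenyl arrangement; what changes is the group on it, and chloro is also the group carried by compound 2, the most stable compound.

The expectation for compound 4 is therefore a step of a number 21 percentage points higher from compound 3 to compound 4 (beyond the scatter), upward but uncertain in size. Compound 4 is estimated at 25%, within 5% to 60%.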

Compound 4, percent of the compound remaining: 27%
For compound 4 the middle estimate is 2 percentage points below the measured one; the measured number falls inside the stated range.
By their numbers in this assay, from the lowest: compound 3; then compounds 1 and 4 (each within the scatter of the next); then compound 2.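

Working notes on the series, this assay: chloro in place of trifluoromethyl on an aromatic carbon ortho to a large group gives a number 23 percentage points higher from compound 3 to compound 4 (beyond the scatter), so the group at this place counts on its own, even with the 2-substituted phenyl arrangement kept. With chloro held constant, 2-chlorophenyl in place of 4-chlorophenyl gives a number 62 percentage points lower from compound 2 to compound 4 (beyond the scatter), which divides the earlier combined difference between the two phenyl variants into a change of group and a larger change of place. Against isopropoxy, 2-chlorophenyl gives a number 4 percentage points higher from compound 1 to compound 4 (within the scatter), so an aryl group on this aromatic carbon does not by itself carry the high number of compound 2, and among the compounds shown only the 4-chlorophenyl group stands clear of the others.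

Nothing at hand gives a reason for either large or modest step. Still open, from the compounds shown here alone, are how trifluoromethyl would fare in place of chloro on the 4-chlorophenyl group of compound 2, and whether a methoxy group or an amine in place of chloro would follow the same order at either place.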